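This account rests on a few compounds, and the source may have more. Where it says the series, first, only, none or still open, it means among the compounds named here.

Compound 1 `CC1OC(n2c(=O)n(C)c3c(O)nc(N)nc32)[C@H](O)[C@@H]1O` — 0%
Compound 2 `COc1ccc(Cn2c(=O)n(C3OC(CO)[C@@H](O)[C@H]3O)c3nc(N)nc(O)c32)cc1` — 44%
Compound 3 `C=CCn1c(=O)n([C@@H]2O[C@H](CO)[C@H]3OC(=O)O[C@H]32)c2nc(N)nc(O)c21` — 50%

Of the compounds shown here, three sharing one core have been measured in a functional assay on the whole organism (B cells) with Mus musculus as the target; a higher number here means a larger maximal response, a lower number a smaller maximal response. Compound 1 gives 0%, so no response at all is seen for it. Compound 2 gives 44%, and compound 3 gives 50%. Of the three numbers, compound 2 stands far above compound 1, a gap that lies beyond the scatter of the measurement, while compound 2 and compound 3 lie within the scatter of each other, so nothing can be said about which of these two reaches the larger maximal response.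

Compound 4 `N#Cc1ccc(Cn2c(=O)n(C3OC(CO)[C@@H](O)[C@H]3O)c3nc(N)nc(O)c32)cc1` has not yet been measured. It differs from compound 2 in a single place: cyano in place of methoxy on an aromatic carbon. Within the data shown here, no measured pair in this set carries a comparable change, so there is no step on record to lean on; the only guide is the value of compound 2 itself in this assay, 44%.

Given that absence, the step of a number 4 percentage points lower from compound 2 to compound 4 (within the scatter) is expected to be small, in no particular direction, and not clearly beyond the scatter. For compound 4 in this assay a maximal response of about 40% is estimated, within a range from 15% to 65%.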

Compound 4, largest response reached (reported as maximal response), in percent of the reference or control that the assay uses: 50%
Estimate against measurement, compound 4: 10 percentage points below, within the range that was stated.
By their numbers in this assay, from the lowest: compound 1; then compounds 2, 3 and 4 (each within the scatter of the next).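

Cyano in place of methoxy on an aromatic carbon, para to a large group, gives a number 6 percentage points higher from compound 2 to compound 4 (within the scatter) in this assay, the first single change on record in this set. The 4-cyanobenzyl group of compound 4 and the 4-methoxybenzyl group of compound 2 cannot be told apart by this read-out, so at this place on the ring a maximal response is kept when one group is exchanged for the other. No measurement shown offers an explanation for this result.

The compounds shown leave open whether the response would also hold with a group of another kind at this place, such as an amine or a carboxylic acid, or with a longer chain in place of the cyano group. They also leave open whether the same exchange would read alike on other compounds of the shared core: the change is seen in one pair only, and a single step within the scatter gives no trend to carry over to them.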